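The source may hold more compounds than are shown below. What is called first, only, known or untested is meant among the compounds shown, and "the series" means these compounds.

Measured in a functional assay on HT-29 cells (Homo sapiens) for inhibition, read by MTT assay, with a stated time of 72 h; on this read-out higher numbers stand for weaker inhibition and lower numbers for stronger inhibition:
- compound 1 `COc1cc(Oc2cccc(Nc3ccccc3)c2)cc(OC)c1CNCc1ccc(F)cc1` gives 2750 nM
- compound 2 `COc1cc(Oc2cccc(Nc3ccccc3)c2)cc(OC)c1CN[C@H](C)c1ccccc1` gives 5120 nM

Among the measured compounds shown here, on these two numbers, compound 2 cannot be told apart from its only neighbour: the gap is a 1.9-fold higher number from compound 1 to compound 2 (0.27 log units; within the scatter), so neither compound can be ranked above the other.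

Compound 3 `COc1cc(Oc2cccc(Nc3ccccc3)c2)cc(OC)c1CN(C)C` keeps the shared core and changes one group: dimethylamino in place of (1-phenylethyl)amino on a saturated chain carbon bound to an aromatic carbon. In words, dimethylamino stands in place of (1-phenylethyl)amino on a saturated chain carbon bound to an aromatic carbon.

For the measured compounds named here, the one measured step, a 1.9-fold higher number from compound 1 to compound 2 (0.27 log units; within the scatter), is only a limited guide. It exchanges 4-fluorobenzyl for 1-phenylethyl on an amine nitrogen, and both of these groups carry an aromatic ring. Going by the values given here, compound 3 has no such ring on that nitrogen, and no measured compound shows what losing it does. The data therefore give no direction, and no shift beyond the scatter is expected in this assay, although the uncertainty is wide. The expected step is a 1.1-fold lower number from compound 2 to compound 3 (0.06 log units; within the scatter), which is an estimate only. For compound 3 the estimated value is 4500 nM, with an expected range of 1400 nM to 15000 nM.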

Compound 3, half-maximal inhibitory concentration: > 20000 nM
Compound 3 ended at the assay's limit (the forecaster's own chance of this, stated with the estimate: 15%); middle value at least 4.4-fold (0.64 log units) from the limit.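

In this assay compound 3 gives > 20000 nM, which is a limit of the assay and not a number: the limit of > 20000 nM in this assay, at which 1 of the 3 values shown sits.

The exchange of 4-fluorobenzyl for 1-phenylethyl stayed within the scatter, but losing the aromatic ring from this nitrogen gives steps beyond it: an at least 3.9-fold higher number from compound 2 to compound 3 (0.59 log units; beyond the scatter) and an at least 7.2-fold higher number from compound 1 to compound 3 (0.86 log units; beyond the scatter). So the group on this saturated chain carbon bound to an aromatic carbon does matter, and the two amines carrying a six-membered aromatic ring of carbon only give measurable numbers, while dimethylamino reaches the limit.

Dimethylamino differs from both larger groups in several ways at once, since it has no ring, fewer heavy atoms and no hydrogen-bond donor, so the compounds shown leave open which of these differences counts. Benzyl(methyl)amino, which keeps the ring but has no amine hydrogen, and methylamino, which keeps the amine hydrogen but has no ring, are the kinds of group that could pull these differences apart.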